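From benzyl to 4-chlorophenyl on the amide-type nitrogen

The compounds below may be only part of what the source reports. "The series", "measured", "known", "first", "only" and "open" are said of these compounds alone.

Within the data shown here, in a functional assay on U-373MG ATCC cells (Homo sapiens) for inhibition, read by MTT assay, with a stated time of 72 h (a higher number here means a weaker inhibitor, a lower number a stronger inhibitor), only two compounds sharing this core have been measured so far. Compound 1 `CC1(C)CC(NC(=S)Nc2ccc([N+](=O)[O-])cc2)c2cc(Br)ccc2O1` stands at 9000 nM and is the stronger inhibitor of the pair. Compound 2 `CC1(C)CC(NC(=S)NCc2ccccc2)c2cc(Br)ccc2O1` stands at 29000 nM with the higher of the two numbers, and the gap between them lies beyond the usual scatter.

The next compound is compound 3 `CC1(C)CC(NC(=S)Nc2ccc(Cl)cc2)c2cc(Br)ccc2O1` with 4-chlorophenyl in place of benzyl on an amide-type nitrogen and the rest of the structure unchanged. Among the measured compounds shown here, no measured pair differs in one place only, so this change has no direct precedent. For the measured compounds named here, the only guide is compound 1 at 9000 nM which also has a substituted phenyl rather than benzyl on that nitrogen, and a single compound sets no rule.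

A lower number is expected in this assay with the estimated step of a 2.6-fold lower number from compound 2 to compound 3 (0.42 log units; beyond the scatter) lying modestly beyond the scatter. Compound 3 is estimated at 11000 nM with an expected range of 4000 nM to 28000 nM in this measurement.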

Compound 3, half-maximal inhibitory concentration: 7000 nM
Compound 3: the middle estimate sits 1.6-fold (0.20 log units) above what was measured, within the range that was stated.
By their numbers in this assay, from the lowest: compounds 3 and 1 (each within the scatter of the next); then compound 2.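

In this assay the replacement now has a direct one-place reading: 4-chlorophenyl in place of benzyl on the amide-type nitrogen gives a 4.1-fold lower number from compound 2 to compound 3 (0.62 log units; beyond the scatter) and so counts as a modest gain at this position, which the earlier pair, differing in more than one place, could not show. The second one-place comparison, chloro in place of nitro on an aromatic carbon, gives a 1.3-fold lower number from compound 1 to compound 3 (0.11 log units; within the scatter) and stays within the scatter, so these two ring substituents cannot be told apart in this assay and neither can be ranked above the other. Nothing available on these compounds accounts for the size of either step.

Still open, going by these compounds, is whether the gain over benzyl comes with the aryl ring sitting directly on the nitrogen or depends on a ring substituent at all, a question that plain phenyl on this nitrogen would settle. Also open, on these data alone, is how far the flat response to chloro and nitro extends, for instance to a methoxy group or an amine on the ring, and whether a longer chain such as 2-phenylethyl lies further along the direction set by benzyl.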